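The compounds below may be only part of what the source reports. "The series", "measured", "known", "first", "only" and "open" are said of these compounds alone.

Measured in an ADME assay on HeLa cells (Homo sapiens) for cytotoxicity, read by MTT assay, with a stated time of 72 h; a lower number here means that less compound is tolerated, a higher number that more compound is tolerated:
- compound 1 `Nc1sc2c(c1-c1nc3ccccc3s1)CCCC2`: 475 ug/mL
- compound 2 `Clc1ccccc1/C=N/c1sc2c(c1-c1nc3ccccc3s1)CCC2`: 138 ug/mL

Compound 1, at 475 ug/mL, holds the higher of the two numbers in this assay. Compound 2, at 138 ug/mL, lies lower, and the gap between the two values is beyond the scatter. Two values are too few to establish a pattern in the series.

The next compound to be measured is compound 3 `Clc1ccccc1/C=N/c1sc2c(c1-c1nc3ccccc3s1)CCCC2`. Relative to compound 1, the change is a group of 9 heavy atoms (7 carbon, 1 nitrogen, 1 chlorine; one six-membered aromatic ring of carbon only) in place of one nitrogen atom, on an aromatic carbon. In short, a group of 9 heavy atoms takes the place of one nitrogen atom on an aromatic carbon.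

Among the compounds with values here, no pair of measured compounds isolates this change, so its size cannot be read directly from the data. Within the data shown here, the only guide is that compound 2, which also bears the entering group, stands at 138 ug/mL. A step downward in this assay, beyond the scatter, is therefore expected, meaning that less compound would be tolerated. The expected step is a 3.2-fold lower number from compound 1 to compound 3 (0.50 log units; beyond the scatter). For compound 3 the estimated value is 150 ug/mL, with an expected range of 65 ug/mL to 340 ug/mL.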

Compound 3, half-maximal cytotoxic concentration: 407 ug/mL
Compound 3: the middle estimate sits 2.7-fold (0.43 log units) below what was measured; measured number outside the range, above it.
By their numbers in this assay, from the lowest: compound 2; then compounds 3 and 1 (each within the scatter of the next).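

At the aromatic carbon next to the ring sulfur, replacing amino with the group of 9 heavy atoms gives a 1.2-fold lower number from compound 1 to compound 3 (0.07 log units; within the scatter) in this assay, so on the core of compound 1 this change cannot be told apart from repeat-measurement noise. Bearing the entering group therefore does not by itself go with a low number: in this assay compound 2 stands at 138 ug/mL and compound 3 stands at 407 ug/mL with the same group in place, and these two differ in one place in the shared core. No supporting measurement bears on why this exchange leaves the reading so little moved.

As far as these compounds go, how a carboxylic acid or a methylamine at this aromatic carbon would read in this assay remains open. Also open, from the compounds shown here alone, is what the chlorine contributes to the entering group, and whether the result for compound 3 would carry over to the core of compound 2 with other groups at this place.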